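Adding a chlorine to the shared core of compound 3

The source may hold more compounds than are shown below. What is called first, only, known or untested is meant among the compounds shown, and "the series" means these compounds.

Of the compounds shown here, three have been tested in an ADME assay on HeLa cells (Homo sapiens) for cytotoxicity, read by MTT assay, with a stated time of 72 h; on this read-out higher numbers stand for lower toxicity in this test and lower numbers for higher toxicity in this test. Compound 1 `Nc1sc2c(c1-c1nc3cc(Cl)ccc3s1)CCC2` gives 75.1 ug/mL. Compound 2 `Clc1ccc(/C=N/c2sc3c(c2-c2nc4ccccc4s2)CCC3)cc1` gives 380 ug/mL. Compound 3 `Oc1ccccc1/C=N/c1sc2c(c1-c1nc3ccccc3s1)CCC2` gives 168 ug/mL, the second highest of the three numbers; compound 3 sits between compound 1 and compound 2, and both of those gaps lie beyond the scatter. Among the compounds with values here, the one step measured so far is a 2.3-fold lower number from compound 2 to compound 3 (0.35 log units; beyond the scatter), a modest change from swapping the group on the carbon with a double bond to nitrogen.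

Compound 4 `Oc1ccccc1/C=N/c1sc2c(c1-c1nc3cc(Cl)ccc3s1)CCC2` differs from compound 3 in another place: chloro in place of hydrogen on an aromatic carbon, on an aromatic carbon of a six-membered aromatic ring of carbon only, part of a fused system of two rings, meta to a fused ring and para to a fused ring. Within the data shown here, no measured step isolates this change, because compound 1 carries the same chlorine but also differs elsewhere, so its value cannot be read as a step. The step from compound 3 to compound 4 in this assay is therefore expected to be a 1.1-fold lower number from compound 3 to compound 4 (0.05 log units; within the scatter), no change beyond the scatter. Compound 4 is expected to give about 150 ug/mL, with a range from 60 ug/mL to 350 ug/mL.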

Compound 4, half-maximal cytotoxic concentration: 251 ug/mL
The estimate for compound 4 lay 1.7-fold (0.22 log units) below the measured number, within the range that was stated.
By their numbers in this assay, from the lowest: compound 1; then compounds 3, 4 and 2 (each within the scatter of the next, the first and the last beyond it).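

In this assay the change of hydrogen to chloro on this aromatic carbon, meta to a fused ring and para to a fused ring, gives a 1.5-fold higher number from compound 3 to compound 4 (0.17 log units; within the scatter) and so does not shift the number beyond the usual scatter when 2-hydroxyphenyl sits on the carbon with a double bond to nitrogen. With the chlorine held constant, a group of 9 heavy atoms in place of one nitrogen atom gives a 3.3-fold higher number from compound 1 to compound 4 (0.52 log units; beyond the scatter) and this modest step, unlike the chloro step, lies beyond the scatter. Nothing available here explains either step.

Only hydrogen and chloro are shown on this aromatic carbon, so the effect of a methoxy group or an amine there remains open. Also open, as far as these compounds go, is whether chloro would give a similar step with 4-chlorophenyl in place of 2-hydroxyphenyl.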